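A few compounds are considered here, and "the series" means these few. Any claim that something is new, unique, unknown or untested is made for them only; others in the source may bear on it.

Measured in an ADME assay on Karpas-1106P cells (Homo sapiens) for cytotoxicity; a lower number here means that less compound is needed, a higher number that more compound is needed for the effect:
Compound 1 `Cc1ccc(S(=O)(=O)N[C@@H](CC(=O)NC(C)(C)C)C(=O)NCCNC(=O)c2ccc(F)cc2)cc1`: > 11100 nM
Compound 2 `Cc1ccc(S(=O)(=O)N[C@@H](CC(=O)NC(C)(C)C)C(=O)NCCNC(=O)c2cccc(C#N)c2)cc1`: > 11100 nM

Compound 1 reads > 11100 nM, and this is a limit of the assay, not a number. Compound 2 likewise gives only a limit, > 11100 nM. Both compounds therefore stand at the same point: the limit of > 11100 nM in this assay, at which 2 of the 2 values shown sit.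

Compound 3 `Cc1ccc(S(=O)(=O)N[C@@H](CC(=O)NC(C)(C)C)C(=O)NCCNC(=O)c2ccccn2)cc1` carries pyridin-2-yl in place of 3-cyanophenyl on a carbonyl carbon whose other neighbour is an amide-type nitrogen, and otherwise keeps the core of compound 2. The difference counts as follows: pyridin-2-yl in place of 3-cyanophenyl on a carbonyl carbon.

Among the measured compounds shown here, only one measured step bears on this place, the exchange of 4-fluorophenyl for 3-cyanophenyl on the same carbonyl carbon. It reads a step that the two limits leave unreadable from compound 1 to compound 2, so it offers no size to carry over. The expectation in this assay rests on compound 2, whose reading of > 11100 nM is a limit.

No step beyond the scatter is expected, and compound 3 will most likely also be reported as a limit. The estimated change is a number no higher from compound 2 to compound 3 (the limit leaves the size open). For compound 3 the estimated value is 11100 nM, with an expected range from 6000 nM to 20000 nM.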

Compound 3, half-maximal effective concentration: > 11100 nM
Compound 3: only a limit was reported; the forecaster's own chance of this, stated with the estimate: 85%; the middle value sits exactly at the limit.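

In this assay compound 3 gives > 11100 nM, which is a limit of the assay and not a number. No step can be read among compound 1, compound 2 and compound 3, which all stand at one point: the limit of > 11100 nM in this assay, at which 3 of the 3 values shown sit.

The compounds shown leave open how 4-fluorophenyl, 3-cyanophenyl and pyridin-2-yl on this carbonyl carbon compare in this assay.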